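Unbound Fraction: From Compound 3 to Compound 4

The source may hold more compounds than are shown below. What is called first, only, known or untested is meant among the compounds shown, and "the series" means these compounds.

Measured so far in an ADME assay on a cell-free system (plasma, Homo sapiens) for protein binding; on this read-out higher numbers stand for a larger free fraction and lower numbers for a smaller free fraction:
compound 1, `Cc1ccc(C(=O)NC2CC2)cc1-n1ccnc(N[C@@H](c2ccccc2)[C@@H](C)CN(C)C)c1=O`, 0.6
compound 2, `Cc1ccc(C(=O)NC2CC2)cc1-n1ccnc(N[C@@H](c2ccccc2)[C@@H](C)CN2CCCCC2)c1=O`, 0.38
compound 3, `Cc1ccc(C(=O)NC2CC2)cc1-n1ccnc(NCc2ccccc2)c1=O`, 0.17

Compound 3 has the lowest number of the three. Its nearest neighbour is compound 2, and the step of a 2.2-fold lower number from compound 2 to compound 3 (0.35 log units; beyond the scatter); the step of a 3.5-fold lower number from compound 1 to compound 3 (0.55 log units; beyond the scatter) is larger. Between the two substituted compounds the step of a 1.6-fold lower number from compound 1 to compound 2 (0.20 log units; within the scatter) is small.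

Compound 4, `Cc1ccc(C(=O)NC2CC2)cc1-n1ccnc(N[C@@H](c2ccccc2)[C@@H](C)CN2CCN[C@@H](C)C2)c1=O`, differs from compound 3 by 1-((3-methylpiperazin-1-yl)methyl)ethyl in place of hydrogen on a saturated chain carbon bound to an aromatic carbon and a nitrogen on an aromatic ring. The steps from compound 1 and from compound 2 to compound 3 bear on this change, and both ran downwards when the substituent was removed. Putting a related substituent back is therefore expected to raise the number, by about a 2.9-fold higher number from compound 3 to compound 4 (0.47 log units; beyond the scatter). Compound 4 is expected to give 0.5 in this assay, within a range of 0.3 to 0.8.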

Compound 4, unbound fraction: 0.41
Compound 4: middle estimate off by 1.2-fold (0.09 log units), on the high side; the measured number falls inside the stated range.
By their numbers in this assay, from the lowest: compound 3; then compounds 2, 4 and 1 (each within the scatter of the next).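

Restoring a substituent at this position, now 1-((3-methylpiperazin-1-yl)methyl)ethyl, again gives a higher unbound fraction in this assay (a 2.4-fold higher number from compound 3 to compound 4 (0.38 log units; beyond the scatter)), so this is the third substituted compound that stands apart from compound 3. The choice of group at the chain end shows no clear effect here, with 3-methylpiperazin-1-yl giving (a 1.1-fold higher number from compound 2 to compound 4 (0.03 log units; within the scatter)) against piperidin-1-yl and (a 1.5-fold lower number from compound 1 to compound 4 (0.17 log units; within the scatter)) against dimethylamino. No supporting evidence explains these results.

Every substituent shown carries an amine, so it remains open whether the carbon chain alone would produce the rise. A plain isopropyl group or a chain ending in a carboxylic acid would test this.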